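Swapping a ring for a chain in compound 2

This account rests on a few compounds, and the source may have more. Where it says the series, first, only, none or still open, it means among the compounds named here.

Compound 1 `CC(C)c1n[nH]c2c(NCc3ccc(-c4ccccn4)cc3)nc(N3CCCCC3CCO)nc12`: 142 nM
Compound 2 `CC(C)c1n[nH]c2c(NCc3ccc(-c4ccccn4)cc3)nc(N[C@@H]3CCCC[C@H]3N)nc12`: 427 nM

In a functional assay on HCT-116 cells (Homo sapiens) for cytotoxicity, read by fluorescence, with a stated time of 72 h (a higher number here means a weaker inhibitor, a lower number a stronger inhibitor), compound 2 gives 427 nM as the higher of the two numbers, which makes it the weaker inhibitor of the pair. In compound 3 `CC(C)c1n[nH]c2c(NCc3ccc(-c4ccccn4)cc3)nc(NCCN(C)C)nc12` 2-(dimethylamino)ethyl stands in place of 2-aminocyclohexyl on a nitrogen on an aromatic ring (2-(dimethylamino)ethyl in place of 2-aminocyclohexyl on a nitrogen on an aromatic ring). Within the data shown here, only one measured step bears on this: a 3.0-fold higher number from compound 1 to compound 2 (0.48 log units; beyond the scatter) is a modest change that also swapped the group carrying the 2-aminocyclohexyl. It shows that such swaps can move the number, but it does not cover this exact change and gives no direction for it. In this assay no clear step beyond the scatter is therefore expected, though one of similar size either way remains possible. The estimated step is a 1.1-fold lower number from compound 2 to compound 3 (0.03 log units; within the scatter) in size. For compound 3 the estimated value is 400 nM (140 nM to 1200 nM).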

Compound 3, half-maximal inhibitory concentration: 390 nM
Estimate against measurement, compound 3: 1.0-fold (0.01 log units) above, within the range that was stated.
By their numbers in this assay, from the lowest: compound 1; then compounds 3 and 2 (each within the scatter of the next).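

In this assay, putting 2-(dimethylamino)ethyl in place of 2-aminocyclohexyl gives a 1.1-fold lower number from compound 2 to compound 3 (0.04 log units; within the scatter), so on this nitrogen on an aromatic ring, the ring and defined stereocentres of the old group can go without a step beyond the scatter. Compound 1, with its 2-(2-hydroxyethyl)piperidin-1-yl group, stays apart from the new chain too, with a 2.7-fold higher number from compound 1 to compound 3 (0.44 log units; beyond the scatter) as the step, and so holds the lowest number of the three. No outside evidence explains these numbers.

The compounds shown leave open whether the amine in the chain matters at all. A 2-hydroxyethyl chain or a plain ethyl chain on the same nitrogen could speak to that, and a longer 3-(dimethylamino)propyl chain could show how much the chain length counts.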